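The compounds below may be only part of what the source reports. "The series", "measured", "known", "first", "only" and "open" are said of these compounds alone.

Compound 1 `COc1ccc(-c2nc(N3CCNCC3)nc3ccccc23)c(OC)c1`: 50 ug/mL
Compound 2 `c1ccc2c(c1)ccn2-c1nc(N2CCNCC2)nc2ccccc12`: 4 ug/mL

In a functional assay on KB cells (Homo sapiens) for antiproliferative activity, read by MTT assay (on this read-out higher numbers stand for weaker inhibition and lower numbers for stronger inhibition), compound 1 gives 50 ug/mL, the higher of the two numbers and beyond the usual scatter of compound 2, which gives 4 ug/mL. Compound 3 `COc1cc(OC)c(-c2nc(N3CCNCC3)nc3ccccc23)c(OC)c1` keeps the core of compound 1 and differs from it by methoxy in place of hydrogen on an aromatic carbon, with methoxy in place of hydrogen on an aromatic carbon. Among the compounds with values here, no measured pair shows what such a change does, so no step beyond the scatter is expected in this assay. The estimated step is a 1.3-fold lower number from compound 1 to compound 3 (0.10 log units; within the scatter). For compound 3 the expected value is 40 ug/mL, within an estimated range of 12 ug/mL to 100 ug/mL.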

Compound 3, half-maximal inhibitory concentration: 50 ug/mL
Estimate against measurement, compound 3: 1.3-fold (0.10 log units) below, within the range that was stated.
By their numbers in this assay, from the lowest: compound 2; then compounds 1 and 3 (each within the scatter of the next).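

In this assay, within the data shown here, methoxy in place of hydrogen on an aromatic carbon, ortho to a large group and meta to two methoxy groups, gives no change at the digits printed from compound 1 to compound 3 (within the scatter), the first measured reading of this change. Among these compounds, this position therefore accepts the added methoxy without a step beyond the scatter, which the earlier compounds could not show. No measurement shown here explains this result. The compounds shown leave open whether an amine or a carboxylic acid on this same carbon would give a different number.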